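Adding a dichlorobenzylsulfanyl group to a weak cytotoxic core

The compounds below may be only part of what the source reports. "The series", "measured", "known", "first", "only" and "open" are said of these compounds alone.

Measured compounds:
Compound 1, `Cc1cc(N2CC[C@@H](C)[C@@H](N(C)c3ncnc4[nH]ccc34)C2)n2ncnc2n1`: 67400 nM
Compound 2, `CCc1cc(N2CC[C@@H](C)[C@@H](N(C)c3ncnc4[nH]ccc34)C2)n2ncnc2n1`: 82200 nM

In a functional assay on BGC-823 cells (Homo sapiens) for inhibition, read by MTT assay, with a stated time of 72 h (on this read-out higher numbers stand for weaker inhibition and lower numbers for stronger inhibition), compound 1 gives 67400 nM, the lowest of the two numbers shown, and compound 2 gives 82200 nM. The step of a 1.2-fold higher number from compound 1 to compound 2 (0.09 log units; within the scatter) is within the scatter, so neither compound can be called stronger than the other.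

Compound 3, `Cc1cc(N2CC[C@@H](C)[C@@H](N(C)c3ncnc4[nH]ccc34)C2)n2nc(SCc3cc(Cl)ccc3Cl)nc2n1`, carries (2,5-dichlorobenzyl)sulfanyl in place of hydrogen on an aromatic carbon. Going by the values given here, the one measured step concerns methyl in place of hydrogen on a saturated chain carbon and therefore does not bear on this change; no measured pair touches the aromatic carbon between two ring nitrogen atoms. The expectation for compound 3 in this assay thus rests only on compound 1 and its value 67400 nM, with a wide range in either direction. Compound 3 is estimated at 50000 nM, between 8000 nM and 200000 nM, and the expected step of a 1.3-fold lower number from compound 1 to compound 3 (0.13 log units; within the scatter) is not beyond the scatter.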

Compound 3, half-maximal inhibitory concentration: 18900 nM
Estimate against measurement, compound 3: 2.6-fold (0.42 log units) above; measured number inside the range.
By their numbers in this assay, from the lowest: compound 3; then compounds 1 and 2 (each within the scatter of the next).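

Going by these compounds alone, the aromatic carbon between two ring nitrogen atoms accepts a large substituent: in this assay, (2,5-dichlorobenzyl)sulfanyl in place of hydrogen gives a 3.6-fold lower number from compound 1 to compound 3 (0.55 log units; beyond the scatter), the first step in this set beyond the scatter. This is therefore the first place in the series where the number responds to a change, but the gain is modest and compound 3 still gives 18900 nM. Nothing available accounts for the shift.

With only this one substituent shown at that carbon, it remains open whether the gain depends on the sulfur, the benzyl ring or the two chlorine atoms. An unsubstituted benzylsulfanyl, a methylsulfanyl or an amine at the same carbon would help separate these parts.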